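Swapping the aryl group of compound 3 for furan-2-yl

The source may report more compounds than this note shows. Statements on the series, on what has been measured and on what is new or still open speak of the compounds shown alone.

Measured in a functional assay on NCI-H460 cells (Homo sapiens) for antiproliferative activity, read by MTT assay, with a stated time of 48 h; on this read-out lower numbers stand for stronger inhibition and higher numbers for weaker inhibition:
- compound 1 `COc1ccc(-c2nc3cccc(-c4cc(OC)c(OC)c(OC)c4)c3o2)cc1`: 3500 nM
- compound 2 `COc1cc(-c2cccc3nc(-c4cccc(Cl)c4)oc23)cc(OC)c1OC`: > 25000 nM, which is a limit of the assay
- compound 3 `COc1cc(-c2nc3cccc(-c4cc(OC)c(OC)c(OC)c4)c3o2)ccc1O`: 2000 nM

On these numbers, compound 3 cannot be separated from its nearest neighbour: a 1.8-fold lower number from compound 1 to compound 3 (0.24 log units; within the scatter). Its other measured step is large: an at least 12-fold lower number from compound 2 to compound 3 (1.09 log units; beyond the scatter).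

Compound 4 `COc1cc(-c2cccc3nc(-c4ccco4)oc23)cc(OC)c1OC` carries furan-2-yl in place of 4-hydroxy-3-methoxyphenyl on an aromatic carbon. Among the compounds with values here, all the measured steps change the group at this same place, and their sizes vary widely. Besides the two above, there is an at least 7.1-fold higher number from compound 1 to compound 2 (0.85 log units; beyond the scatter). Within the data shown here, no measured compound carries furan-2-yl, so these steps give only a rough guide. Since the 3-chlorophenyl swap in compound 2 gave an at least 12-fold lower number from compound 2 to compound 3 (1.09 log units; beyond the scatter), a clear move to a higher number is expected, though not necessarily up to the limit. The expected change is a 4.5-fold higher number from compound 3 to compound 4 (0.65 log units; beyond the scatter). For compound 4 the estimated value is 9000 nM, with an expected range from 2500 nM to 30000 nM.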

Compound 4, half-maximal inhibitory concentration: 2600 nM
Estimate against measurement, compound 4: 3.5-fold (0.54 log units) above; measured number inside the range.
By their numbers in this assay, from the lowest: compounds 3, 4 and 1 (each within the scatter of the next). At a limit, above all of these: compound 2.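

In this assay, furan-2-yl at this place on the five-membered ring of the shared core cannot be separated from either larger aryl group: a 1.3-fold higher number from compound 3 to compound 4 (0.11 log units; within the scatter), and a 1.3-fold lower number from compound 1 to compound 4 (0.13 log units; within the scatter). Among the compounds shown, then, neither a six-membered aromatic ring of carbon only nor the hydrogen-bond donor of compound 3 is required for a value in this range, and only 3-chlorophenyl stands apart: an at least 9.6-fold lower number from compound 2 to compound 4 (0.98 log units; beyond the scatter). The value of compound 2 is a limit, so this step gives only a bound on the real gap: the limit of > 25000 nM in this assay, at which 1 of the 4 values shown sits.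

As far as these compounds go, whether thiophen-2-yl, an unsubstituted phenyl or a saturated ring such as cyclohexyl would fit at this place as well as furan-2-yl stays open. So does whether the chlorine itself sets compound 2 apart, which a 3-methoxyphenyl or 4-chlorophenyl group could help to settle.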